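Swapping Benzyl for Tert-Butyl on a Fluorinated Nitrone

This account rests on a few compounds, and the source may have more. Where it says the series, first, only, none or still open, it means among the compounds named here.

Compound 1 `[O-]/[N+](=C\c1cn(CCC(F)(F)C(F)(F)C(F)(F)C(F)(F)C(F)(F)C(F)(F)F)nn1)Cc1ccccc1` bears a benzyl group on the nitrone nitrogen and a fluorinated chain on the shared core. In a functional assay on MDA-MB-231 cells (Homo sapiens) for inhibition, read by MTT assay, with a stated time of 24 h (on this read-out higher numbers stand for weaker inhibition and lower numbers for stronger inhibition), compound 1 reaches only the limit of > 100000 nM, which is a limit of the assay rather than a number (the limit of > 100000 nM in this assay, at which 1 of the 3 values shown sits). Compound 2 `[O-]/[N+](=C\c1cn(CCC(F)(F)C(F)(F)C(F)(F)C(F)(F)C(F)(F)C(F)(F)C(F)(F)C(F)(F)F)nn1)Cc1ccccc1` gives 8400 nM in this assay, and the step of an at least 11-fold lower number from compound 1 to compound 2 (1.07 log units; beyond the scatter) is the only measured one, altering the chain and not the nitrogen substituent. Compound 3 `CCCCCCCCCCn1cc(/C=[N+](\[O-])C(C)(C)C)nn1` gives 20800 nM with a tert-butyl group but a different chain. Compound 4 `CC(C)(C)/[N+]([O-])=C/c1cn(CCC(F)(F)C(F)(F)C(F)(F)C(F)(F)C(F)(F)C(F)(F)F)nn1` differs from compound 1 by tert-butyl in place of benzyl on a double-bonded nitrogen. Among the compounds with values here, no measured step covers this change, so no direction beyond the scatter is expected. Compound 4 is estimated at 60000 nM (from 15000 nM to 150000 nM), an expected step of an at least 1.6-fold lower number from compound 1 to compound 4 (0.22 log units; that floor lies within the scatter).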

Compound 4, half-maximal inhibitory concentration: 9800 nM
Estimate against measurement, compound 4: 6.1-fold (0.79 log units) above; measured number below the stated range.
By their numbers in this assay, from the lowest: compounds 2 and 4 (each within the scatter of the next); then compound 3. At a limit, above all of these: compound 1.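

Tert-butyl in place of benzyl on the double-bonded nitrogen gives an at least 10-fold lower number from compound 1 to compound 4 (1.00 log units; beyond the scatter) in this assay, so with the chain unchanged, the nitrogen substituent alone moves the read-out beyond the scatter. The value of compound 1 is a limit and not a number, so this step gives only a floor: the limit of > 100000 nM in this assay, at which 1 of the 4 values shown sits. The compounds shown leave open whether a cyclohexyl or isopropyl group on this nitrogen would give a similar number, and what tert-butyl would give on the longer fluorinated chain of compound 2.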